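The compounds below may be only part of what the source reports. "The series", "measured", "known", "first", "only" and "open" are said of these compounds alone.

Three compounds have been measured in an ADME assay on Huh-7 cells (Homo sapiens) for cytotoxicity, read by MTT assay, with a stated time of 96 h; on this read-out lower numbers stand for higher toxicity in this test and higher numbers for lower toxicity in this test:

Compound 1 `COc1cc(NCc2scnc2C)ccc1-c1cnco1`: 58500 nM
Compound 2 `COc1cc(/N=C/c2ccc(F)cc2)ccc1-c1cnco1`: > 100000 nM (a limit of the assay)
Compound 3 `COc1cc(/N=C/c2ccncc2)ccc1-c1cnco1`: > 100000 nM (a limit of the assay)

Compound 1 is the only one of the three with a number, at 58500 nM. The other two stand at a limit, as the limit of > 100000 nM in this assay, at which 2 of the 3 values shown sit, shows, so neither can be ranked against it. Compound 4 `COc1cc(NCc2cncs2)ccc1-c1cnco1` differs from compound 1 in one place, (hydrogen in place of methyl on an aromatic carbon), with hydrogen in place of methyl on an aromatic carbon. Among the compounds with values here, the only measured step, a step that the two limits leave unreadable from compound 2 to compound 3, concerns another part of the structure and has no readable size, so it does not bear on this change. The expectation therefore rests on compound 1 alone, with its 58500 nM, and no shift beyond the usual scatter is expected in this assay. The expected step is a 1.1-fold higher number from compound 1 to compound 4 (0.05 log units; within the scatter), with no clear direction. For compound 4 the estimated value is 65000 nM, within an expected range of 30000 nM to 100000 nM.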

Compound 4, half-maximal cytotoxic concentration: 68900 nM
The estimate for compound 4 lay 1.1-fold (0.03 log units) below the measured number; the measured number falls inside the stated range.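

In this assay, within the data shown here, hydrogen in place of methyl on this aromatic carbon, next to the ring nitrogen, gives a 1.2-fold higher number from compound 1 to compound 4 (0.07 log units; within the scatter), the first step that can be read as a number. On the thiazole of compound 1 and compound 4, then, this methyl can be exchanged for hydrogen without a step beyond the scatter in this test. The earlier step could not show this, and compound 2 and compound 3 stay unranked against compound 1 and compound 4, as both of their values are limits: the limit of > 100000 nM in this assay, at which 2 of the 4 values shown sit.

As far as these compounds go, how a larger group at this carbon, such as an ethyl, a trifluoromethyl or an amine, would read in this assay stays open. So does whether the same exchange of methyl for hydrogen would read alike on another core.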